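A Fluorine on the Aniline Ring of Compound 1

The source may hold more compounds than are shown below. What is called first, only, known or untested is meant among the compounds shown, and "the series" means these compounds.

Measured compounds:
compound 1, `CC(C)(C)c1cc(NC(=O)Nc2ccc(Nc3ncnc4c3OCCN4)cc2)no1`: 58 nM
compound 2, `O=C(Nc1ccc(Nc2ncnc3c2OCCN3)cc1)Nc1cccs1`: > 10000 nM

Among the measured compounds shown here, in an assay on isolated protein for inhibition of proto-oncogene tyrosine-protein kinase receptor Ret variant V804L (Homo sapiens), read by 33P incorporation, with stated times of 15 min and 40 min (a higher number here means a weaker inhibitor, a lower number a stronger inhibitor), compound 1 gives 58 nM, which is the only plain number among the two values shown. For compound 2 the assay returns only a limit, > 10000 nM, and not a number. For the measured compounds named here, the single measured step, an at least 170-fold higher number from compound 1 to compound 2 (2.23 log units; beyond the scatter), rests on the limit of > 10000 nM in this assay, at which 1 of the 2 values shown sits, and concerns the group at the far end of the urea, not the ring that carries the anilino nitrogen.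

Compound 3, `CC(C)(C)c1cc(NC(=O)Nc2ccc(Nc3ncnc4c3OCCN4)cc2F)no1`, differs from compound 1 by fluoro in place of hydrogen on an aromatic carbon. Going by the values given here, no measured pair in this set changes that ring, so the one step known here bears only indirectly on this exchange and gives no direction for it. Compound 1 therefore serves as the sole anchor, and for compound 3 a step within the usual scatter is expected, a 1.0-fold higher number from compound 1 to compound 3 (0.01 log units; within the scatter). The estimate for compound 3 in this assay is 60 nM, with a range from 20 nM to 200 nM, and a modest chance that only a limit is returned.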

Compound 3, half-maximal inhibitory concentration: 95 nM
Beside the measured number, compound 3's estimate is 1.6-fold (0.20 log units) below it; the measured number falls inside the stated range.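

In this assay, among the compounds shown here, compound 3 gives the first reading of a change on the six-membered aromatic ring of carbon only: fluoro in place of hydrogen on an aromatic carbon, ortho to a large group and meta to a large group, comes to a 1.6-fold higher number from compound 1 to compound 3 (0.21 log units; within the scatter), so this single atom leaves the reading no further from that of compound 1 than repeated measurements would. Compound 2, changed instead at the far end of the urea, returns only a limit, > 10000 nM, which makes this aromatic carbon the first place in the series where a step can be read as a plain number on both sides. Nothing given here speaks to the reason for this reading.

From the compounds shown here alone, whether a larger group on the same aromatic carbon, such as chloro, methyl or methoxy, would also stay within the scatter remains open. So does the reading of fluoro on the other carbons of this ring, and of fluoro combined with a different group at the far end of the urea.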